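A second fluorine on the phenyl ring of compound 2

The compounds below may be only part of what the source reports. "The series", "measured", "known", "first", "only" and "open" are said of these compounds alone.

Of the two compounds measured in a functional assay on CHO cells for positive allosteric modulation of metabotropic glutamate receptor 2 (Homo sapiens), with a stated time of 30 min (on this read-out higher numbers stand for an effect only at larger amounts of compound and lower numbers for an effect already at smaller amounts), compound 2 `N#Cc1c(N2CCC(c3cccc(F)c3)CC2)ccn(CC2CC2)c1=O` stands lowest, at 141 nM, and the only other one, compound 1 `CC(C)CCn1ccc(N2CCN(c3ccccc3)CC2)c(C#N)c1=O`, gives 661 nM, a gap beyond the scatter. The unmeasured compound 3 `N#Cc1c(N2CCC(c3ccc(F)cc3F)CC2)ccn(CC2CC2)c1=O` differs from compound 2 by 2,4-difluorophenyl in place of 3-fluorophenyl on a saturated ring carbon. Among the measured compounds shown here, no measured pair shows this change, so nothing here fixes its direction; the step is expected to stay small, about within the scatter, as a 1.1-fold higher number from compound 2 to compound 3 (0.05 log units; within the scatter). Compound 3 is accordingly estimated at 160 nM, with a likely range from 50 nM to 500 nM.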

Compound 3, half-maximal effective concentration: 68 nM
Compound 3: middle estimate off by 2.4-fold (0.37 log units), on the high side; measured number inside the range.
By their numbers in this assay, from the lowest: compound 3; then compound 2; then compound 1.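

Among the compounds shown here, on the aryl group carried by a saturated ring carbon of the six-membered ring, replacing 3-fluorophenyl with 2,4-difluorophenyl gives in this assay a 2.1-fold lower number from compound 2 to compound 3 (0.32 log units; beyond the scatter) and so provides the first single-place comparison here. It shows that this position responds to the fluorine pattern, with a modest step beyond the scatter. No measurement shown accounts for the step.

As far as these compounds go, because the change alters both the number and the placement of fluorines, their separate contributions remain open. From the compounds shown here alone, whether chlorine or methoxy on the phenyl ring would lower the number further also remains open.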